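Swapping an aryl group back toward an ether in a fused core

The source may report more compounds than this note shows. Statements on the series, on what has been measured and on what is new or still open speak of the compounds shown alone.

Compound 3 `COc1cccc(CNCCCNc2ccnc3cc(-c4ccc(C(C)(C)C)cc4)ccc23)c1O`: 32000 nM
Compound 1 `COc1cccc(CNCCCNc2ccnc3cc(Oc4ccccc4)ccc23)c1O`: 14500 nM
Compound 2 `COc1ccc(F)cc1CNCCCNc1ccnc2cc(Oc3ccc(F)cc3)ccc12`: 14500 nM

In a physicochemical assay for solubility, with a stated time of 18 h, at pH 7.4 (on this read-out lower numbers stand for lower solubility and higher numbers for higher solubility), compound 3 gives the highest of the three numbers, with compound 1 and compound 2 each sitting lower by a margin beyond the scatter. Compound 4 `COc1cccc(Oc2ccc3c(NCCCNCc4cccc(OC)c4O)ccnc3c2)c1` differs from compound 3 by one change: 3-methoxyphenoxy in place of 4-(tert-butyl)phenyl on an aromatic carbon. Among the compounds with values here, the only measured step that bears on this is a 2.2-fold higher number from compound 1 to compound 3 (0.34 log units; beyond the scatter), which went the opposite way, from an ether-linked ring to a carbon-linked ring. Reversing that kind of change is expected to lower the number by a modest step, a 2.0-fold lower number from compound 3 to compound 4 (0.30 log units; within the scatter). Compound 4 is therefore estimated at 16000 nM, within a range of 7000 nM to 35000 nM.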

Compound 4, solubility: 14500 nM
Beside the measured number, compound 4's estimate is 1.1-fold (0.04 log units) above it; the range from low to high includes it.
By their numbers in this assay, from the lowest: compounds 1, 2 and 4 (each within the scatter of the next); then compound 3.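

In this assay, 3-methoxyphenoxy in place of 4-(tert-butyl)phenyl gives a 2.2-fold lower number from compound 3 to compound 4 (0.34 log units; beyond the scatter), so a substituted ether-linked ring also reads lower than the carbon-linked ring. Methoxy in place of hydrogen on the phenoxy ring gives no change at the digits printed from compound 1 to compound 4 (within the scatter), so this substituent on the ether-linked ring makes no visible difference. No measurement here explains either result. As far as these compounds go, compound 3 carries both the carbon link and the tert-butyl group, so it remains open which of them goes with its higher number. From the compounds shown here alone, how a plain phenyl, or a ring bearing an amine or a carboxylic acid, would read at this position also remains open.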